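The compounds below may be only part of what the source reports. "The series", "measured", "known", "first", "only" and "open" are said of these compounds alone.

Measured in a physicochemical assay for solubility, read by LC-MS, in phosphate buffer, with a stated time of 24 h, at pH 7.4; a higher number here means a more soluble compound, a lower number a less soluble compound:
- compound 1 `CC(=O)Nc1cc(Nc2cc(NC3CC3)n3ncc(C#N)c3n2)ccc1NCCCO`: 2000 nM
- compound 2 `CC(=O)Nc1cc(Nc2cc(NC3CC3)n3ncc(C#N)c3n2)ccc1N1CC[C@H](N(C)C)C1`: > 800000 nM, a limit of the assay

Compound 2 gives no exact number, only a limit: the limit of > 800000 nM in this assay, at which 1 of the 2 values shown sits. Its true position is therefore open on the upper side, and any comparison with it has to be read with that in mind.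

Compound 3 `CC(=O)Nc1cc(Nc2cc(NC3CC3)n3ncc(C#N)c3n2)ccc1N1CCC[C@@H](N(C)C)C1` has not yet been measured. It differs from compound 2 at one place, on an aromatic carbon ortho to an acetamido group: a group of 9 heavy atoms (7 carbon, 2 nitrogen; one six-membered non-aromatic ring with 1 hetero atom) in place of a group of 8 heavy atoms (6 carbon, 2 nitrogen; one five-membered non-aromatic ring with 1 hetero atom), on an aromatic carbon. The 3-(dimethylamino)pyrrolidin-1-yl group leaves, and a six-membered non-aromatic ring enters.

Going by the values given here, only one measured step bears on this place. It is large, an at least 400-fold higher number from compound 1 to compound 2 (2.60 log units; beyond the scatter), and it brought in a non-aromatic ring of the kind that compound 3 also carries. Among the compounds with values here, no measured step changes the size of that ring, so this expectation rests on a single pair. A change from the five-membered to the six-membered ring is expected to do little, with no shift beyond the scatter or a small fall at most. The expected step is an at least 1.3-fold lower number from compound 2 to compound 3 (0.12 log units; that floor lies within the scatter). For compound 3 the estimate is 600000 nM, with an expected range of 150000 nM to 1000000 nM.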

Compound 3, solubility: > 900000 nM
Compound 3: a limit, no number; the forecaster's own chance of this, stated with the estimate: 50%; middle value at least 1.5-fold (0.17 log units) away from the limit.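

Putting the group with the six-membered non-aromatic ring in place of (3-hydroxypropyl)amino gives an at least 450-fold higher number from compound 1 to compound 3 (2.65 log units; beyond the scatter), so the large rise first seen with 3-(dimethylamino)pyrrolidin-1-yl is not confined to the five-membered ring. In this assay compound 3 gives only a limit of the assay, > 900000 nM. Compound 2 also gives only a limit, > 800000 nM, so the step between these two compounds cannot be read, and the values cannot tell whether the change from the five-membered to the six-membered ring has any effect on the number.

Going by these compounds, it remains open whether the large rise over compound 1 goes with the non-aromatic ring itself or with the dimethylamino group on it, a question that a hydroxyl group on the same ring or an open chain ending in a dimethylamino group would address. Also open, on these data alone, is how the opposite configuration at the defined stereocentre of either ring would read in this assay, and how far compound 2 and compound 3 truly lie from each other.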